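The compounds below may be only part of what the source reports. "The series", "measured", "known", "first", "only" and "open" are said of these compounds alone.

Measured in a physicochemical assay, read by spectrophotometry, with a stated time of 15 min; a higher number here means a weaker inhibitor, a lower number a stronger inhibitor:
- compound 1 `O=C(CCc1nc2ccccc2c(=O)[nH]1)N/N=C/c1ccc(O)c(O)c1`: 105000000 nM
- compound 2 `COc1cc(/C=N/NC(=O)CCCc2nc3ccccc3c(=O)[nH]2)ccc1O`: 280000000 nM
- compound 3 `COc1cc(/C=N/NC(=O)CCCc2nc3ccccc3c(=O)[nH]2)cc(O)c1O`: 80000000 nM

On these numbers, compound 1 cannot be told apart from compound 3, and its number is clearly lower than that of compound 2.

Compound 4 `COc1cc(/C=N/NC(=O)CCc2nc3ccccc3c(=O)[nH]2)cc(O)c1O` is compound 1 with one change, a methoxy in place of hydrogen on an aromatic carbon.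

Within the data shown here, no measured step shows this exact change. The closest is the modest 3.5-fold lower number from compound 2 to compound 3 (0.54 log units; beyond the scatter), which puts hydroxy in place of hydrogen on an aromatic carbon, so it involves a different group. Compound 3 carries the same groups on its aromatic ring as compound 4 and differs from it only in the chain. Since compound 3 gives 80000000 nM, close to compound 1, no step beyond the scatter is expected in this assay.

The expected change is small: a 1.2-fold lower number from compound 1 to compound 4 (0.07 log units; within the scatter).

The estimated value for compound 4 is 90000000 nM, with an expected range of 40000000 nM to 200000000 nM.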

Compound 4, half-maximal inhibitory concentration: 50000000 nM
The estimate for compound 4 lay 1.8-fold (0.26 log units) above the measured number; the range from low to high includes it.
By their numbers in this assay, from the lowest: compounds 4, 3 and 1 (each within the scatter of the next, the first and the last beyond it); then compound 2.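

In this assay, placing a methoxy on the ring carbon ortho to one hydroxy group and meta to the other gives a 2.1-fold lower number from compound 1 to compound 4 (0.32 log units; beyond the scatter). This step is modest but beyond the scatter, so this ring position can carry a methoxy with no rise in the number. Among these compounds, the only earlier step on this ring was a hydroxy entering on a different chain, a 3.5-fold lower number from compound 2 to compound 3 (0.54 log units; beyond the scatter), so a lower number now follows both changes, and both end with the same groups on the ring. Nothing available explains why the methoxy lowers the number.

The compounds shown leave open whether an ethoxy, a chlorine or an amine at this position would also lower the number. They also leave open whether a methoxy here would have the same effect on a longer chain.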